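Side-chain amine swap on the flavone core: compound 3

The compounds below may be only part of what the source reports. "The series", "measured", "known", "first", "only" and "open" are said of these compounds alone.

Going by the values given here, compound 1 `COc1cc(OC)c2c(=O)c(OCCCCN3CCCCC3)c(-c3cc(OC)c(OC)c(OC)c3)oc2c1` is the weaker of the two measured members: in a functional assay on MGC-803 cells (Homo sapiens) for cytotoxicity, read by MTT assay, with a stated time of 38 h (on this read-out lower numbers stand for stronger inhibition and higher numbers for weaker inhibition), compound 1 gives 26800 nM, the highest number of the two. Among the compounds with values here, compound 2 `COc1cc(OC)c2c(=O)c(OCC(=O)N/N=C/c3ccco3)c(-c3cc(OC)c(OC)c(OC)c3)oc2c1` gives 6050 nM, and the step of a 4.4-fold lower number from compound 1 to compound 2 (0.65 log units; beyond the scatter) is the only measured step so far.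

Compound 3 `CCN(CC)CCCOc1c(-c2cc(OC)c(OC)c(OC)c2)oc2cc(OC)cc(OC)c2c1=O` is not yet measured. It differs from compound 1 as follows: diethylamino in place of (piperidin-1-yl)methyl on a saturated chain carbon, three bonds along the chain from an oxygen on an aromatic ring. Within the data shown here, the one measured step replaces the whole ring-bearing part of the side chain at the oxygen on the aromatic ring, so it does not speak directly to an exchange of one amine for another at this distance along the chain. Among the measured compounds shown here, with no step bearing on the change, no movement beyond the scatter is expected, and the estimated step of a 1.1-fold lower number from compound 1 to compound 3 (0.03 log units; within the scatter) is small. Compound 3 is therefore expected to give about 25000 nM, with a range from 10000 nM to 60000 nM.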

Compound 3, half-maximal inhibitory concentration: 40200 nM
For compound 3 the middle estimate is 1.6-fold (0.21 log units) below the measured one; low and high end bracket the measured number.
By their numbers in this assay, from the lowest: compound 2; then compounds 1 and 3 (each within the scatter of the next).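

In this assay, diethylamino in place of (piperidin-1-yl)methyl, on a saturated chain carbon three bonds along the chain from an oxygen on an aromatic ring, gives a 1.5-fold higher number from compound 1 to compound 3 (0.18 log units; within the scatter), so this first exchange of one amine for another does not separate the two compounds. The side chain of compound 2 remains apart from both amine chains, with a 6.6-fold higher number from compound 2 to compound 3 (0.82 log units; beyond the scatter), as it did against compound 1. No measurement on hand gives a reason for either step.

The same difference reads as 4-(piperidin-1-yl)butyl to 3-(diethylamino)propyl, so the ring and the chain change together, and compound 1 and compound 3 cannot tell them apart. On these data alone, it remains open whether a 4-(diethylamino)butyl chain, or a morpholine at the chain end, would move the number away from these two compounds.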